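The compounds below may be only part of what the source reports. "The series", "measured", "known", "first", "only" and "open" are said of these compounds alone.

Measured in a functional assay on PANC-1 cells (Homo sapiens) for cytotoxicity, read by MTT assay, with a stated time of 72 h; on this read-out lower numbers stand for stronger inhibition and higher numbers for weaker inhibition:

Compound 1, `Cc1ccc(-c2ccc(NC3=CC(=O)c4ncncc4C3=O)cc2F)cc1`: 4800 nM
Compound 2, `COc1cc(NC2=CC(=O)c3ncncc3C2=O)cc(OC)c1OC`: 800 nM
Compound 3, `COc1ccc(-c2ccc(NC3=CC(=O)c4ncncc4C3=O)cc2)cc1`: 2300 nM

Among these three values compound 3 stands second highest. Its nearest neighbour is compound 1, whose value is higher by more than the usual scatter, and its furthest is compound 2, whose value is lower by more than the scatter.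

Compound 4, `NS(=O)(=O)c1ccc(NC2=CC(=O)c3ncncc3C2=O)cc1`, has not yet been measured in this assay. It differs from compound 3 in one place: sulfamoyl in place of 4-methoxyphenyl on an aromatic carbon. The new group sits on an aromatic carbon of a six-membered aromatic ring of carbon only, para to a large group. For the measured compounds named here, no measured pair shows a step of this kind, so the direction rests on judgment alone. For compound 4 a weakening beyond the scatter is expected, a step of a 2.2-fold higher number from compound 3 to compound 4 (0.34 log units; beyond the scatter). Compound 4 is therefore estimated at 5000 nM, with a range from 1500 nM to 20000 nM.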

Compound 4, half-maximal inhibitory concentration: > 10000 nM
Compound 4: a limit, no number; the forecaster's own chance of this, stated with the estimate: 10%; middle value at least 2.0-fold (0.30 log units) away from the limit.
By their numbers in this assay, from the lowest: compound 2; then compound 3; then compound 1. At a limit, above all of these: compound 4.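

At this position, on an aromatic carbon para to a large group, sulfamoyl in place of 4-methoxyphenyl gives an at least 4.3-fold higher number from compound 3 to compound 4 (0.63 log units; beyond the scatter) in this assay. For the compounds shown here, this is the first direct view of this place, and it shows that the cytotoxic effect does not survive every change there. Compound 4 gives a limit of the assay and not a number, so the true size of the step stays unknown: the limit of > 10000 nM in this assay, at which 1 of the 4 values shown sits.

As far as these compounds go, whether the loss follows from removing the outer ring or from the sulfamoyl itself stays open. A small group such as an amine or a carboxylic acid at this place could help separate the two.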